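Ethylsulfanyl for ethylamino on the shared core

The source may report more compounds than this note shows. Statements on the series, on what has been measured and on what is new or still open speak of the compounds shown alone.

Working notes on the series. Three compounds carry numbers in a functional assay (spleen, spleen) for activation, with Mus musculus as the target; on this read-out higher numbers stand for an effect only at larger amounts of compound and lower numbers for an effect already at smaller amounts. Compound 2 `CCNc1nc(N)c2nc(O)n(Cc3ccccc3)c2n1` gives 1 uM, the lowest of the two numbers shown. Compound 1 `COc1ccc(Cn2c(O)nc3c(N)ncnc32)cc1` gives 10 uM, a higher number that lies beyond the scatter. Compound 3 `Nc1ncnc2c1nc(O)n2C1CCCC1` returns only a limit, > 10 uM, not a number. Compound 3 thus sits at the limit of > 10 uM in this assay, at which 1 of the 3 values shown sits. Compound 4 `CCSc1nc(N)c2nc(O)n(Cc3ccccc3)c2n1` has not yet been measured. It differs from compound 2 in one place: ethylsulfanyl in place of ethylamino on an aromatic carbon. Within the data shown here, no step between measured compounds covers this exchange, so the direction rests on the change alone. A modest rise in the number is expected, a 3.0-fold higher number from compound 2 to compound 4 (0.48 log units; beyond the scatter). Compound 4 is estimated at 3 uM in this assay, within 1 uM to 10 uM.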

Compound 4, minimum effective concentration: 0.1 uM
Compound 4: middle estimate off by 30-fold (1.48 log units), on the high side; measured number below the stated range.
By their numbers in this assay, from the lowest: compound 4; then compound 2; then compound 1.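

On the aromatic carbon between two ring nitrogen atoms, ethylsulfanyl in place of ethylamino gives a 10-fold lower number from compound 2 to compound 4 (1.00 log units; beyond the scatter) in this assay, so this position responds strongly to the exchange. The hydrogen-bond donor of ethylamino, absent from ethylsulfanyl, is therefore not needed for a low number on the shared core. Nothing measured here bears on why the number falls.

This rests on a single pair of compounds. As far as these compounds go, whether ethoxy or a longer chain such as butylsulfanyl on the same carbon would give a lower or higher number stays open.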